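The source may hold more compounds than are shown below. What is called first, only, known or untested is meant among the compounds shown, and "the series" means these compounds.

In an ADME assay on BJ cells (Homo sapiens) for cytotoxicity, read by CellTiter-Glo and resazurin assay, with a stated time of 72 h (on this read-out lower numbers stand for an effect already at smaller amounts and higher numbers for an effect only at larger amounts of compound), compound 3 (`CC(C)N(Cc1cccc(OCCCCCC(=O)O)c1)C(=O)c1ccc(-c2cccc(Br)c2)cc1`) gives > 26000 nM, a limit and not a number. It stands at the limit of > 26000 nM in this assay, at which 2 of the 3 values shown sit. Compound 1 (`CC(C)COc1cccc(-c2ccc(C(=O)N(Cc3cccc(OCCCCCC(=O)O)c3)C(C)C)cc2)c1`) gives > 26000 nM, also a limit. Compound 2 (`CCOc1cccc(-c2ccc(C(=O)N(Cc3cccc(OCCCCCC(=O)O)c3)C(C)C)cc2)c1`) gives > 20800 nM, likewise a limit. Compound 4 (`CC(C)N(Cc1cccc(OCCCCCC(=O)O)c1)C(=O)c1ccc(-c2cccc(Cl)c2)cc1`) follows from compound 3 by chloro in place of bromo on an aromatic carbon, in words chloro in place of bromo on an aromatic carbon, 3-bromophenyl to 3-chlorophenyl. The measured steps nearest to this change are a step that the two limits leave unreadable from compound 1 to compound 3 and a step that the two limits leave unreadable from compound 2 to compound 3. Neither gives a size to carry over, so the expectation in this assay is no step beyond the scatter, with another limit the likely report. The expected step is a number no higher from compound 3 to compound 4 (the limit leaves the size open). For compound 4 the estimate is 26000 nM, with an expected range of 18000 nM to 40000 nM.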

Compound 4, half-maximal effective concentration: > 21900 nM
Compound 4: only a limit was reported; the forecaster's own chance of this, stated with the estimate: 90%; the middle value is on the limit's open side.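

In this assay compound 4, like compound 1, compound 2 and compound 3, is reported only as a limit, so no step among these compounds can be read. The compounds shown leave open where any of them reaches a half-maximal effect.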